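The source may report more compounds than this note shows. Statements on the series, on what has been measured and on what is new or still open speak of the compounds shown alone.

Measured so far in a functional assay on DU-145 cells (Homo sapiens) for inhibition, read by trypan blue exclusion, with a stated time of 96 h; a higher number here means a weaker inhibitor of growth, a lower number a stronger inhibitor of growth:
compound 1, `Cc1ccc(S/C(=C/c2ccc(Cl)cc2)C(=O)c2ccc(Cl)cc2)cc1`: 10000 nM
compound 2, `Cc1ccc(S/C(=C/c2cc(C)cc(C)c2)C(=O)c2ccc(Cl)cc2)cc1`: 50000 nM
compound 3, `Cc1cc(C)cc(/C=C(/Sc2ccc(Br)cc2)C(=O)c2ccc(Cl)cc2)c1`: 10000 nM

Compound 2 has the highest number of the three; compound 1 and compound 3 both lie beyond the scatter below it. Compound 4, `Cc1ccc(S/C(=C/c2ccc(Cl)cc2Cl)C(=O)c2ccc(Cl)cc2)cc1`, has not been measured. The change from compound 2 to compound 4 is 2,4-dichlorophenyl in place of 3,5-dimethylphenyl on a double-bonded chain carbon bound to a double-bonded chain carbon. The step that bears on it is a 5.0-fold higher number from compound 1 to compound 2 (0.70 log units; beyond the scatter), in which 4-chlorophenyl gave way to 3,5-dimethylphenyl and the number rose. Compound 4 brings back a chlorine-substituted phenyl, here 2,4-dichlorophenyl, so something like the reverse of that step is expected. The other step, a 5.0-fold lower number from compound 2 to compound 3 (0.70 log units; beyond the scatter), concerns bromo in place of methyl on an aromatic carbon and says nothing directly about 2,4-dichlorophenyl. Within the data shown here, no measured compound carries a second chlorine on this ring, so the estimate leans on compound 1 alone and the range is kept wide. For compound 4 the expected step is a 5.0-fold lower number from compound 2 to compound 4 (0.70 log units; beyond the scatter), a fall beyond the scatter. The estimate for compound 4 in this assay is 10000 nM, with a range from 3000 nM to 40000 nM.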

Compound 4, concentration for 50% growth inhibition: 10000 nM
Compound 4: the middle estimate sits on the measured number at the digits printed; measured number inside the range.
By their numbers in this assay, from the lowest: compounds 1, 3 and 4 (each within the scatter of the next); then compound 2.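

In this assay the change on a double-bonded chain carbon bound to a double-bonded chain carbon gives a 5.0-fold lower number from compound 2 to compound 4 (0.70 log units; beyond the scatter) and so joins a 5.0-fold higher number from compound 1 to compound 2 (0.70 log units; beyond the scatter) in setting 3,5-dimethylphenyl apart, now from two chlorine-bearing phenyl groups rather than one. The series also gains its first reading of a second chlorine on this ring, with no change at the digits printed from compound 1 to compound 4 (within the scatter) for chloro in place of hydrogen on an aromatic carbon, so 4-chlorophenyl and 2,4-dichlorophenyl cannot be told apart in this assay. No supporting measurement accounts for either step.

A 4-methylphenyl or a 3,5-dichlorophenyl at this carbon would show whether the higher number of compound 2 follows the methyl groups themselves or the way they are arranged on the ring. On these data alone, how an amine or a carboxylic acid on this ring would read remains open.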